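The compounds below may be only part of what the source reports. "The series", "measured", "known", "first", "only" and "open" are said of these compounds alone.

Measured so far in an ADME assay on Vero cells (Chlorocebus sabaeus) for cytotoxicity, with a stated time of 7 days; a higher number here means that more compound is tolerated, a lower number that less compound is tolerated: compound 1 `COc1ccc2[nH]c(C(=O)N3CC(=O)N(Cc4ccccc4)[C@@H](CN4CCC5(CC4)CC5)C3)cc2c1` gives 17100 nM; compound 3 `COc1ccc2[nH]c(C(=O)N3CC(=O)N(Cc4c[nH]c5ccccc45)[C@@H](Cc4ccccc4)C3)cc2c1` gives 7200 nM. Compound 2 `COc1ccc2[nH]c(C(=O)N3CC(=O)N(Cc4cccc(OC)n4)[C@@H](Cc4ccccc4)C3)cc2c1` gives only a limit, > 30000 nM.

Compound 1 has the highest of the two numbers reported; compound 3 sits nearest to it, with a step between them beyond the scatter. Compound 2 is at the limit of this assay, (the limit of > 30000 nM in this assay, at which 1 of the 3 values shown sits), so no number is known for it.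

Among the measured compounds shown here, the only measured step, an at least 4.1-fold lower number from compound 2 to compound 3 (0.61 log units; beyond the scatter), swaps the group on the saturated chain carbon bound to the amide-type nitrogen in the ring. Compound 4 `COc1ccc2[nH]c(C(=O)N3CC(=O)N(Cc4ccccc4)[C@@H](Cc4ccccn4)C3)cc2c1` instead differs from compound 1 on the other chain carbon: a group of 6 heavy atoms (5 carbon, 1 nitrogen; one six-membered aromatic ring with 1 hetero atom) in place of a group of 8 heavy atoms (7 carbon, 1 nitrogen; one three-membered non-aromatic ring of carbon only, one six-membered non-aromatic ring with 1 hetero atom), on a saturated chain carbon bound to a saturated ring carbon. For the measured compounds named here, no measured pair changes that position, so the measured step bears on compound 4 only loosely, as a sign that the numbers in this set move within a modest band.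

The expected step is therefore a 1.2-fold lower number from compound 1 to compound 4 (0.09 log units; within the scatter), a small one in the direction of compound 3. For compound 4 a value of 14000 nM is expected, in a range from 6000 nM to 30000 nM.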

Compound 4, half-maximal cytotoxic concentration: > 30000 nM
Compound 4: a limit, no number; the forecaster's own chance of this, stated with the estimate: 25%; middle value at least 2.1-fold (0.33 log units) from the limit.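

In this assay, putting pyridin-2-yl in place of the group of compound 1, on a saturated chain carbon bound to a saturated ring carbon, gives an at least 1.7-fold higher number from compound 1 to compound 4 (0.24 log units; that floor lies within the scatter). Among the compounds shown here, this is the first reading at this position, and it shows that the aromatic ring is tolerated there at least as well as the group it replaces, though the floor of the step does not separate the two compounds firmly. Compound 4 gives a limit and not a number, and with compound 2 it sits at that limit: the limit of > 30000 nM in this assay, at which 2 of the 4 values shown sit.

On these data alone, it remains open how large the step really is, and whether a plain piperidin-1-yl on that chain carbon would read like compound 1 or compound 4. As far as these compounds go, the effect of a carboxylic acid or a dimethylamino group at this position also remains open.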